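The source may report more compounds than this note shows. Statements on the series, on what has been measured and on what is new or still open speak of the compounds shown alone.

In a functional assay on MDA-MB-231 cells (Homo sapiens) for cytotoxicity, read by ELISA, with a stated time of 2 days (a lower number here means a stronger inhibitor, a higher number a weaker inhibitor), two compounds on a shared core have been measured. Compound 1 `Oc1cccc(-c2cc(-c3ccccc3)cc(-c3ccsc3)n2)c1`, bearing thiophen-3-yl, gives 12100 nM, and compound 2 `Oc1cccc(-c2cc(-c3ccccc3)cc(-c3ccco3)n2)c1`, bearing furan-2-yl, gives 13700 nM. For the measured compounds named here, these values lie within the scatter of each other, so compound 2 stands level with its only measured neighbour. Compound 3 `Oc1cccc(-c2cc(-c3ccccc3)cc(-c3ccncc3)n2)c1` carries pyridin-4-yl in place of furan-2-yl on an aromatic carbon, next to the ring nitrogen: pyridin-4-yl in place of furan-2-yl on an aromatic carbon. Going by the values given here, the only measured step that bears on this change is a 1.1-fold higher number from compound 1 to compound 2 (0.05 log units; within the scatter). That step exchanged one five-membered aromatic ring for another, whereas the new group is a six-membered aromatic ring, so it is only a loose guide. No shift beyond the scatter is therefore expected in this assay, and neither direction is favoured. The estimated change is a 1.1-fold lower number from compound 2 to compound 3 (0.02 log units; within the scatter). Compound 3 is expected at 13000 nM, with an estimated range from 5000 nM to 35000 nM.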

Compound 3, half-maximal inhibitory concentration: 10400 nM
Estimate against measurement, compound 3: 1.3-fold (0.10 log units) above, and the stated range covers the measured number.
By their numbers in this assay, from the lowest: compounds 3, 1 and 2 (each within the scatter of the next).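

At this place on the shared core, next to the ring nitrogen, a six-membered aromatic ring now stands alongside two five-membered ones, and this assay does not separate them: the steps are a 1.3-fold lower number from compound 2 to compound 3 (0.12 log units; within the scatter) and a 1.2-fold lower number from compound 1 to compound 3 (0.07 log units; within the scatter). Among these three compounds, then, neither ring size nor the kind of hetero atom moves the number beyond the scatter. Nothing measured here speaks to what lies behind this result.

The compounds shown leave open whether a group of another kind at this place, such as an amine, a carboxylic acid or a longer alkyl chain, would move the number beyond the scatter. On these data alone, all three compounds also keep the 3-hydroxyphenyl and phenyl groups, so what changes at those two places does remains open.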